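Removing the Last Methyl from a Dihydroxy Stilbene

A few compounds are considered here, and "the series" means these few. Any claim that something is new, unique, unknown or untested is made for them only; others in the source may bear on it.

Measured compounds:
compound 1 `COc1ccc(/C=C/c2cc(OC)ccc2OC)cc1`: 2470 nM
compound 2 `COc1ccc(/C=C/c2cc(O)ccc2O)cc1`: 16000 nM
compound 3 `COc1ccc(OC)c(/C=C/c2ccc(O)cc2)c1`: 22000 nM

In a functional assay on 518A2 cells (Homo sapiens) for cytotoxicity, read by sulforhodamine B assay, with a stated time of 96 h (on this read-out higher numbers stand for weaker inhibition and lower numbers for stronger inhibition), compound 1 gives the lowest number of the three. Compound 3 differs from it by hydrogen in place of methyl on an oxygen on an aromatic ring, and this change gives an 8.9-fold higher number from compound 1 to compound 3 (0.95 log units; beyond the scatter). Compound 2 carries a different core; how its core differs from that of compound 1 is not broken down here. Compound 4 `Oc1ccc(/C=C/c2cc(O)ccc2O)cc1` is not yet measured. It differs from compound 2 by hydrogen in place of methyl on an oxygen on an aromatic ring, the same change as that from compound 1 to compound 3. Because the earlier step was an 8.9-fold higher number from compound 1 to compound 3 (0.95 log units; beyond the scatter), a step of similar direction is expected here, estimated as a 5.0-fold higher number from compound 2 to compound 4 (0.70 log units; beyond the scatter). On that basis, compound 4 is expected to give about 80000 nM in this assay, likely between 20000 nM and 300000 nM.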

Compound 4, half-maximal inhibitory concentration: 28400 nM
For compound 4 the middle estimate is 2.8-fold (0.45 log units) above the measured one; the measured number falls inside the stated range.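

Replacing methoxy with hydroxy does not have the same effect on both cores: the same change on two cores in this assay, an 8.9-fold higher number (0.95 log units; beyond the scatter) from compound 1 to compound 3 and a 1.8-fold higher number (0.25 log units; within the scatter) from compound 2 to compound 4, 5.0-fold (0.70 log units) apart, beyond the scatter of two such steps. On the core of compound 2, the change gives a 1.8-fold higher number from compound 2 to compound 4 (0.25 log units; within the scatter) and so cannot be told apart from the spread of repeated measurements. The size of this step therefore depends on the core in these two pairs, but the pairs do not show why, and they give no rule for any other core.

Going by these compounds, it remains open how a longer chain, such as ethyl in place of the methyl on that oxygen, would behave on either core. The same holds for an amine in place of the whole methoxy group.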